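The source may report more compounds than this note shows. Statements on the series, on what has been measured and on what is new or still open speak of the compounds shown alone.

Of the compounds shown here, two have been measured. Compound 1 `CCN(CC)c1nc(Nc2ccc([N+](=O)[O-])cc2)nc(OC(C(F)(F)F)C(F)(F)F)n1` and compound 2 `CCN(CC)c1nc(Nc2ccccc2)nc(OCC(F)(F)C(F)F)n1` share a core and differ in two places, so their values are simply set side by side. In an assay on cells for activation of Cystic fibrosis transmembrane conductance regulator (Homo sapiens), read by fluorescence, with stated times of 10 min and 12 s (a lower number here means that less compound is needed, a higher number that more compound is needed for the effect), compound 1 gives 18000 nM, while in this assay compound 2 gives 2000 nM, the lower of the two numbers, and the gap between them lies beyond the usual scatter. Compound 2 therefore stands as the better of the two measured compounds.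

Compound 3 `CCN(CC)c1nc(Nc2cccc(Cl)c2)nc(OCC(F)(F)C(F)F)n1` has not yet been measured. It differs from compound 2 in one place: chloro in place of hydrogen on an aromatic carbon, turning the anilino group into a (3-chlorophenyl)amino group. For the measured compounds named here, no measured pair in this set carries the same change, so the size of the step can only be guessed. The expectation is a modest move toward a lower number, perhaps no larger than the scatter itself, with the step from compound 2 to compound 3 in this assay estimated as a 2.0-fold lower number from compound 2 to compound 3 (0.30 log units; within the scatter). For compound 3 in this assay the estimate is 1000 nM, with a range from 300 nM to 4000 nM.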

Compound 3, half-maximal effective concentration: 5400 nM
Compound 3: the middle estimate sits 5.4-fold (0.73 log units) below what was measured; the whole stated range lies below it.
By their numbers in this assay, from the lowest: compound 2; then compound 3; then compound 1.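

For the compounds shown here, compound 3 supplies the first comparison that differs in one place only, setting the (3-chlorophenyl)amino group against the plain anilino group with the rest of the molecule unchanged. In this assay, chloro in place of hydrogen on an aromatic carbon, meta to a large group, gives a 2.7-fold higher number from compound 2 to compound 3 (0.43 log units; beyond the scatter), a modest step that nevertheless lies beyond the scatter. This shows that the ring is not indifferent to a change at this position and that this particular chloro group moves the number in the unfavourable direction.

With a single step, the compounds shown cannot tell whether this holds only for chloro or for any group placed there, as a fluoro, a methyl or a methoxy group at the same carbon would begin to show. They also leave open whether chloro on another carbon of the ring would move the number the same way, and whether the same change would have the same effect with a different group on the other side of the shared core. No measurement at hand bears on why the step goes in this direction.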